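The compounds below may be only part of what the source reports. "The series", "measured", "known", "first", "only" and "open" are said of these compounds alone.

Measured compounds:
compound 1 `CC(C)CCn1ccc(-c2ccc(Oc3ccccn3)cc2)c(C#N)c1=O` gives 646 nM
compound 2 `Cc1cc(Oc2ccc(-c3ccn(CC4CC4)c(=O)c3C#N)cc2)ccn1` gives 832 nM

In a functional assay on CHO cells for positive allosteric modulation of metabotropic glutamate receptor 2 (Homo sapiens), read by scintillation counting and GTPgammaS binding, with a stated time of 30 min (on this read-out lower numbers stand for an effect already at smaller amounts and higher numbers for an effect only at larger amounts of compound), compound 1 stands at the lower of the two numbers recorded, while compound 2 sits within the usual scatter of it, so no order between the two can be read from these values. Compound 3 `Cc1ncccc1Oc1ccc(-c2ccn(CCC(C)C)c(=O)c2C#N)cc1` differs from compound 1 in a single place: 2-methylpyridin-3-yl in place of pyridin-2-yl on an oxygen on an aromatic ring. Among the measured compounds shown here, compound 2 differs from compound 1 in two places at once, so it offers no step that isolates this change, and no measured pair here does. With nothing in the data to point in either direction, the step from compound 1 to compound 3 is expected to stay modest, and for compound 3 the estimate is a 1.2-fold higher number from compound 1 to compound 3 (0.09 log units; within the scatter), which is taken as no change beyond the scatter. Compound 3 is therefore expected to give about 800 nM in this assay, within a range from 300 nM to 2500 nM.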

Compound 3, half-maximal effective concentration: 275 nM
Beside the measured number, compound 3's estimate is 2.9-fold (0.46 log units) above it, and the stated range ends above it.
By their numbers in this assay, from the lowest: compound 3; then compounds 1 and 2 (each within the scatter of the next).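

In this assay, among the compounds shown here, the exchange of pyridin-2-yl for 2-methylpyridin-3-yl on the oxygen gives a 2.3-fold lower number from compound 1 to compound 3 (0.37 log units; beyond the scatter), the first step here that lies beyond the scatter, so the group held at this place does bear on the read-out. This single exchange alters two things together, adding a methyl and moving the point at which the pyridine ring is joined to the oxygen, and the step cannot divide its size between them. Nothing measured here accounts for the lower number.

The compounds shown leave open whether the methyl or the new point of attachment carries the step, a question that plain pyridin-3-yl on the same oxygen would address. Also open, going by these compounds, is whether a chlorine or a methoxy group in place of that methyl would give a similar number.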